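The source may hold more compounds than are shown below. What is called first, only, known or untested is meant among the compounds shown, and "the series" means these compounds.

Compound 1 `COC(=O)/C(=C/c1ccccc1)CN1C(=O)[C@@H](OC)[C@H]1c1ccc(Cl)cc1` and compound 2 `COC(=O)/C(=C/c1ccccc1)CN1C(=O)[C@@H](OC)[C@H]1c1cccc(Cl)c1` share one core and differ only in where the chlorine sits on the aromatic ring that hangs from a saturated ring carbon. In a functional assay on MCF7 cells (Homo sapiens) for antiproliferative activity, read by MTT assay, with a stated time of 48 h (on this read-out lower numbers stand for stronger inhibition and higher numbers for weaker inhibition), compound 1 gives 15300 nM and compound 2 gives 25100 nM. Among the compounds with values here, the step of a 1.6-fold higher number from compound 1 to compound 2 (0.21 log units; within the scatter) is too small to separate the two, so compound 2 merely holds the higher of the two numbers measured so far. Compound 3 `COC(=O)/C(=C/c1ccccc1)CN1C(=O)[C@@H](OC)[C@H]1c1ccccc1` has not yet been measured. It differs from compound 2 by hydrogen in place of chloro on an aromatic carbon; read at the level of the whole group, this is 3-chlorophenyl to phenyl. Within the data shown here, no measured step removes a chlorine outright; the only step available, a 1.6-fold higher number from compound 1 to compound 2 (0.21 log units; within the scatter), moves the chlorine from one aromatic carbon to another and stays within the scatter. Since a 1.6-fold higher number from compound 1 to compound 2 (0.21 log units; within the scatter) is that small, the expected step of a 1.3-fold higher number from compound 2 to compound 3 (0.11 log units; within the scatter) is also expected to be small, with only a slight lean toward a higher number. Compound 3 in this assay is therefore estimated at 32000 nM, with a range from 12000 nM to 85000 nM.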

Compound 3, half-maximal inhibitory concentration: 12900 nM
Estimate against measurement, compound 3: 2.5-fold (0.39 log units) above; measured number inside the range.
By their numbers in this assay, from the lowest: compounds 3, 1 and 2 (each within the scatter of the next).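

Until now the chlorine had only moved from one aromatic carbon to another; compound 3 has no chlorine on this ring at all, which tests whether the chlorine matters in the first place. In this assay neither route to the plain phenyl separates the compounds: the steps are a 1.9-fold lower number from compound 2 to compound 3 (0.29 log units; within the scatter) and a 1.2-fold lower number from compound 1 to compound 3 (0.07 log units; within the scatter) and both stay inside the usual scatter. The 4-chlorophenyl, 3-chlorophenyl and phenyl compounds therefore cannot be told apart here, so this read-out shows no need for a chlorine on this ring, and nothing on hand says why the change makes so little difference.

The compounds shown carry only chlorine or hydrogen on this ring, so it stays open whether a different group there, such as an amine or a hydroxyl group, would shift the number beyond the scatter. All three also keep the same methyl ester on the shared core, so the effect of a carboxylic acid in its place is open as well.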